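This account rests on a few compounds, and the source may have more. Where it says the series, first, only, none or still open, it means among the compounds named here.

Values in an ADME assay on cells (Hepatocyte, Rattus norvegicus) for metabolic stability; a higher number here means that the compound lasts longer, a lower number that the compound disappears faster:
- compound 1 `O=C(C1CCN(c2ncccn2)CC1)N1N=CC[C@H]1c1ccccc1`: 0.137 h
- compound 2 `N#Cc1cnc(N2CCC(C(=O)N3N=CC[C@H]3c3cc(F)cc(F)c3)CC2)cn1`: 1.78 h
- compound 3 `CC1=NN(C(=O)C(C)(C)C)[C@H](c2ccccc2)C1`: 0.0417 h

Among these three, compound 2 has the highest number in this assay, at 1.78 h. That lies beyond the scatter of both other compounds, with compound 1 at 0.137 h and compound 3 at 0.0417 h. Within the data shown here, the compounds differ in more than one place, so the series offers no measured step for a single change.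

The next compound, compound 4 `N#Cc1cc(N2CCC(C(=O)N3N=CC[C@H]3c3cc(F)cc(F)c3)CC2)ncn1`, has the same atoms as compound 2, joined differently. The change is a group of 8 heavy atoms (5 carbon, 3 nitrogen; one six-membered aromatic ring with 2 hetero atoms) in place of a group of 8 heavy atoms (5 carbon, 3 nitrogen; one six-membered aromatic ring with 2 hetero atoms), on an amine nitrogen in a ring: the 5-cyanopyrazin-2-yl group gives way to a group with no common name, on an amine nitrogen in a ring. The count of atoms and the kind of ring stay the same, and the rest of the molecule is untouched. With so conservative a change, a large shift is not expected. Compound 2 at 1.78 h is the top value of the three, so any expected movement leans slightly downward. The estimated change is a 1.4-fold lower number from compound 2 to compound 4 (0.14 log units; within the scatter), which would stay within the scatter. For compound 4 the expected half-life is 1.3 h, with an estimated range of 0.5 h to 3.3 h.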

Compound 4, half-life: 1.15 h
Compound 4: middle estimate off by 1.1-fold (0.05 log units), on the high side; low and high end bracket the measured number.
By their numbers in this assay, from the lowest: compound 3; then compound 1; then compounds 4 and 2 (each within the scatter of the next).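

In this assay, among these compounds, the change on the amine nitrogen of the six-membered non-aromatic ring gives a 1.5-fold lower number from compound 2 to compound 4 (0.19 log units; within the scatter), the only step so far that isolates a single place. It shows that, at this position, the 5-cyanopyrazin-2-yl group and its replacement, which has the same heavy-atom count, the same kind of aromatic ring and the same triple bond, cannot be told apart in this measurement, so this rearrangement of the ring nitrogens and the nitrile leaves the read-out within the usual scatter. Nothing measured alongside these compounds bears on why the two stand so close.

The compounds shown leave open how far this tolerance extends, since both groups at this place carry a nitrile on a ring with two nitrogens, and a single pair says nothing about a different substituent there. A methyl, a methoxy or a trifluoromethyl group in place of the nitrile, or a pyridine ring in place of the ring with two nitrogens, with the rest of compound 2 unchanged, would show whether the value depends on those features.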